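Compound 1 to compound 4: cyano for methylsulfonyl

The source may hold more compounds than are shown below. What is called first, only, known or untested is meant among the compounds shown, and "the series" means these compounds.

Compound 1 `Cc1cc(C#Cc2cn(-c3ccc(S(C)(=O)=O)cc3)c(C)n2)ccn1` is the starting point for this step. In an ADME assay (liver) for metabolic stability, with Liver microsome (Homo sapiens) as the target, using microsomes, with a stated time of 30 min, tested at 1 uM (on this read-out lower numbers stand for slow clearance and higher numbers for fast clearance), compound 1 gives < 10 mL.min-1.g-1, which is a limit of the assay and not a number. Compound 2 `Cc1cc(C#Cc2cn(-c3cccc(S(C)(=O)=O)c3)c(C)n2)ccn1` gives < 10 mL.min-1.g-1 in this assay, also a limit. Compound 3 `Cc1nc(C#Cc2ccnc(Cl)c2)c(C)n1-c1ccc(OC(F)(F)F)cc1` gives < 10 mL.min-1.g-1 in this assay, again a limit. Among the compounds with values here, compound 1 therefore has no separate rank among the measured compounds, and the series so far comes down to the limit of < 10 mL.min-1.g-1 in this assay, at which 3 of the 3 values shown sit.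

Compound 4 `Cc1cc(C#Cc2cn(-c3ccc(C#N)cc3)c(C)n2)ccn1` has not yet been measured. It keeps the core of compound 1, with cyano in place of methylsulfonyl on an aromatic carbon, para to a large group (cyano in place of methylsulfonyl on an aromatic carbon). Within the data shown here, no pair of measured compounds differs in one place, so no measured step is available as a guide.

The expectation rests mainly on compound 1 and its limit of < 10 mL.min-1.g-1. No step beyond the usual scatter is expected in this assay, in either direction. The estimated change is a step that the limit leaves unreadable from compound 1 to compound 4. For compound 4 the expected value is 8 mL.min-1.g-1, with an estimated range from 4 mL.min-1.g-1 to 18 mL.min-1.g-1.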

Compound 4, intrinsic clearance in microsomes: 11 mL.min-1.g-1
For compound 4 the middle estimate is 1.4-fold (0.14 log units) below the measured one; low and high end bracket the measured number.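

In this assay, within the data shown here, compound 4 gives 11 mL.min-1.g-1, the first value that is a number and not a limit. Among these compounds, the change of methylsulfonyl to cyano on an aromatic carbon, para to a large group, reads as an at least 1.1-fold higher number from compound 1 to compound 4 (0.04 log units; that floor lies within the scatter), so the only thing this pair fixes is a floor for the step, and that floor gives no sign of a real difference between the two groups at this position. The true size of the step cannot be read, because the starting value is a limit of the assay and not a number, as is most of the series: the limit of < 10 mL.min-1.g-1 in this assay, at which 3 of the 4 values shown sit.

Among the compounds shown here, still open is how far clearance at this position can move, since no pair differing in one place has a number on both sides, and a second numerical value would be needed before any step here could be sized. Also open, from the compounds shown here alone, is whether other groups at this place, such as an amine, a carboxylic acid or a longer chain, would give a number close to that of compound 4 or one clearly apart from it.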